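Swapping 1,1-dimethylprop-2-en-1-yl for allyl

The compounds below may be only part of what the source reports. "The series", "measured", "known", "first", "only" and "open" are said of these compounds alone.

Compound 1 `C=CCc1cc(-c2ccc(OC)cc2)cc(CC=C)c1O` gives 75600 nM
Compound 2 `C=CCc1cc(-c2ccccc2)ccc1O` gives > 100000 nM (a limit)
Compound 3 `C=CC(C)(C)c1cc(-c2ccc(OC)cc2)ccc1O` gives > 100000 nM (a limit)

In a functional assay on A549 cells (Homo sapiens) for antiproliferative activity, read by MTT assay, with a stated time of 24 h (a lower number here means a stronger inhibitor, a higher number a weaker inhibitor), compound 3 stands at > 100000 nM as a limit of the assay and not as a number. Compound 4 `C=CCc1cc(-c2ccc(OC)cc2)ccc1O` carries allyl in place of 1,1-dimethylprop-2-en-1-yl on an aromatic carbon, ortho to a hydroxy group (allyl in place of 1,1-dimethylprop-2-en-1-yl on an aromatic carbon). Within the data shown here, no measured pair shows this change. Only compound 1 gives a true number (75600 nM), so little gain is expected in this assay. A small step toward a lower number, close to the usual scatter, is expected (an at least 1.1-fold lower number from compound 3 to compound 4 (0.04 log units; that floor lies within the scatter)). Compound 4 is estimated at 90000 nM with an expected range from 50000 nM to 150000 nM as its ends.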

Compound 4, half-maximal inhibitory concentration: > 100000 nM
Compound 4 ended at the assay's limit (the forecaster's own chance of this, stated with the estimate: 55%); middle value at least 1.1-fold (0.04 log units) away from the limit.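

In this assay compound 4 also gives only a limit, so allyl in place of 1,1-dimethylprop-2-en-1-yl on this aromatic carbon, ortho to a hydroxy group, yields no true number. Taking away the second allyl of the core gives an at least 1.3-fold higher number from compound 1 to compound 4 (0.12 log units; that floor lies within the scatter). The steps reaching compound 4 from compound 3 and compound 2 cannot be read because both ends of each are limits: the limit of > 100000 nM in this assay, at which 3 of the 4 values shown sit.

From the compounds shown here alone, the true values behind those limits stay open. So does whether an amine or a longer chain on this aromatic carbon would give a true number in this assay.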